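A few compounds are considered here, and "the series" means these few. Any claim that something is new, unique, unknown or untested is made for them only; others in the source may bear on it.

The measured compounds in a functional assay on A549 cells (Homo sapiens) for cytotoxicity, read by CCK-8 assay, with a stated time of 24 h; on this read-out lower numbers stand for stronger inhibition and higher numbers for weaker inhibition:
Compound 1 `C/C(=C\c1cc(-c2cccnc2)co1)C(N)=O` gives 6620 nM.
Compound 2 `C/C(=C\c1cc(-c2ccc(C)cc2)cs1)C(N)=O` gives only a limit of the assay, > 50000 nM.
Compound 3 `C/C(=C\c1cc(-c2ccc(F)cc2)cs1)C(N)=O` likewise gives only a limit of the assay, > 50000 nM.

Compound 3 thus stands at the edge of what this assay reports: its number is not known, only a limit. For the measured compounds named here, of the three values shown, only that of compound 1 is a number, and compound 1 sits well inside the measurable range; but compound 1 differs from compound 3 in more than one place, so the two values say nothing about any single change. Going by the values given here, the one measured step that reaches compound 3 is a step that the two limits leave unreadable from compound 2 to compound 3, and its size is not readable because both of its values sit at the limit of > 50000 nM in this assay, at which 2 of the 3 values shown sit.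

Compound 4 `C/C(=C\c1cc(-c2ccc(S(C)(=O)=O)cc2)cs1)C(N)=O` differs from compound 3 by methylsulfonyl in place of fluoro on an aromatic carbon. No measured step bears on this exchange other than the unreadable one from compound 2, so nothing shown points to a move out of the limit in either direction. Compound 4 is therefore expected to stay at or near the limit, with an estimate of 50000 nM and a range from 20000 nM to 120000 nM. The expected step is a number no higher from compound 3 to compound 4 (the limit leaves the size open), none beyond the scatter.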

Compound 4, half-maximal inhibitory concentration: > 50000 nM
Compound 4: a limit, no number (the forecaster's own chance of this, stated with the estimate: 70%); the middle value lies on the limit itself.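

In this assay compound 4 gives > 50000 nM, which is a limit and not a number. No step among compound 2, compound 3 and compound 4 can be read, because each of them sits at the same limit: the limit of > 50000 nM in this assay, at which 3 of the 4 values shown sit.

The compounds shown leave open whether methyl, fluoro and methylsulfonyl differ at all in this assay.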